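The source may hold more compounds than are shown below. What is called first, only, known or untested is meant among the compounds shown, and "the series" means these compounds.

Compound 1, `CC(=O)c1cc(C(=O)N[C@@H](C)Cn2ccc(-c3cc(F)c(C#N)c(Cl)c3)n2)n[nH]1`: in an ADME assay on PC-3 cells (Homo sapiens) for cytotoxicity, read by CCK-8 assay, with a stated time of 6 days (a lower number here means a stronger inhibitor, a higher number a weaker inhibitor), compound 1 gives > 30000 nM.
Compound 2, `CC(O)c1ccc(C(=O)N[C@@H](C)Cn2ccc(-c3ccc(C#N)c(Cl)c3)n2)cc1`: in this assay compound 2 gives > 30000 nM.

Both of these readings are limits of the assay rather than numbers. For compound 2 the reading is a limit, so its place among the values can only be described as sitting at the edge of what the assay reports. Among the measured compounds shown here, the one further value shown is also a limit, and the limit of > 30000 nM in this assay, at which 2 of the 2 values shown sit, marks where both readings sit.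

Compound 3, `C[C@@H](Cn1ccc(-c2ccc(C#N)c(Cl)c2)n1)NC(=O)C1CC(=O)C1`, has not been measured. It differs from compound 2 in one place: 3-oxocyclobutyl in place of 4-(1-hydroxyethyl)phenyl on a carbonyl carbon. For the measured compounds named here, no step between two measured compounds is available in this set, so nothing measured tells how far such a change moves the reading in this assay. With compound 2 at the limit, compound 3 is expected to show no step beyond the scatter, and the change from compound 2 to compound 3 is estimated as a number no higher from compound 2 to compound 3 (the limit leaves the size open). Compound 3 is therefore estimated at 30000 nM, with a range from 10000 nM to 100000 nM, and most likely the assay will again report only a limit.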

Compound 3, half-maximal inhibitory concentration: > 30000 nM
Compound 3: no number, only a limit; the forecaster's own chance of this, stated with the estimate: 85%; the middle value sits exactly at the limit.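

In this assay compound 3 gives > 30000 nM, which is a limit of the assay and not a number. Compound 2 also stands at a limit, so no step can be read between compound 2 and compound 3: the limit of > 30000 nM in this assay, at which 3 of the 3 values shown sit.

The compounds shown leave open whether 3-oxocyclobutyl in place of 4-(1-hydroxyethyl)phenyl changes the reading at all.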